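Series notes: azole-substituted benzimidazole variation at the six-membered ring

A few compounds are considered here, and "the series" means these few. Any claim that something is new, unique, unknown or untested is made for them only; others in the source may bear on it.

Three compounds of the shared core have numbers in an ADME assay on cells for inhibition of cytochrome P450 11B1, mitochondrial (Homo sapiens), read by HPLC, with a stated time of 60 min; on this read-out higher numbers stand for weaker inhibition and lower numbers for stronger inhibition. Compound 1 `Fc1ccc2nc(-n3ccnn3)n(C3CC3)c2c1` gives 9070 nM. Compound 2 `Fc1cc2nc(-c3cncnc3C3CC3)n(C3CC3)c2cc1F` gives > 10000 nM, which is a limit of the assay and not a number, namely (the limit of > 10000 nM in this assay, at which 1 of the 3 values shown sits). Compound 3 `CN(C)c1ncncc1-c1nc2cc(F)c(F)cc2n1C1CC1` gives 4630 nM. Among the compounds with values here, the one single-point step measured is an at least 2.1-fold lower number from compound 2 to compound 3 (0.33 log units; beyond the scatter). Compound 3 thus holds the lowest of the two numbers reported, with compound 1 nearest, a difference that stays within the scatter, so no order between compound 3 and compound 1 can be read from them.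

Compound 4 `CC(F)(F)c1ncncc1-c1nc2cc(F)c(F)cc2n1C1CC1` is not yet measured. It differs from compound 3 by 1,1-difluoroethyl in place of dimethylamino on an aromatic carbon. Within the data shown here, the only measured step at this position, from compound 2 to compound 3, runs the other way, replacing cyclopropyl with dimethylamino, and was at least modest in size; no measured step introduces 1,1-difluoroethyl anywhere, so the direction of this step rests on no direct precedent. Among the measured compounds shown here, a change of small size in this assay is expected, with a weaker number held as somewhat more likely given that compound 3 is the one compound at this position that reached a number at all, giving an expected step of a 1.4-fold higher number from compound 3 to compound 4 (0.15 log units; within the scatter).

For compound 4 the expected value in this assay is 6500 nM, within a range from 2500 nM to 16000 nM.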

Compound 4, half-maximal inhibitory concentration: 5720 nM
For compound 4 the middle estimate is 1.1-fold (0.06 log units) above the measured one; measured number inside the range.
By their numbers in this assay, from the lowest: compounds 3, 4 and 1 (each within the scatter of the next). At a limit, above all of these: compound 2.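

In this assay, the exchange at this aromatic carbon gives a 1.2-fold higher number from compound 3 to compound 4 (0.09 log units; within the scatter), so dimethylamino and 1,1-difluoroethyl cannot be told apart here, although the leaving group counts 1 hydrogen-bond acceptor and the entering group 0. The change from cyclopropyl to 1,1-difluoroethyl gives an at least 1.7-fold lower number from compound 2 to compound 4 (0.24 log units; that floor lies within the scatter), and that floor alone does not establish a difference between these two groups, unlike the step to dimethylamino, which lies beyond the scatter. The value of compound 2 is a limit of the assay and not a number: the limit of > 10000 nM in this assay, at which 1 of the 4 values shown sits.

Open, on these data alone, is whether a methoxy group, a primary amine or trifluoromethyl on the same aromatic carbon would stay in the range of compound 3 and compound 4, or whether any group there moves the number well away from it. Also open, as far as these compounds go, is how dimethylamino and 1,1-difluoroethyl would compare with a different fluorine pattern on the shared core, since both compounds carry the same one.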